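The compounds below may be only part of what the source reports. "The series", "measured", "known", "first", "only" and "open" are said of these compounds alone.

Measured so far in an assay on HEK293 cells for agonist activity at transient receptor potential cation channel subfamily M member 8 (Homo sapiens), read by fluorescence and calcium flux, with a stated time of 15 min; on this read-out higher numbers stand for an effect only at larger amounts of compound and lower numbers for an effect already at smaller amounts:
compound 1 `CCN(Cc1cccs1)C(=O)c1cc2cc(C)ccc2o1` gives 120 nM;
compound 2 `Cc1ccc2oc(C(=O)N(Cc3cccs3)c3ccn[nH]3)cc2c1` gives 40 nM;
compound 3 `Cc1ccc(/C=C/C(=O)N(Cc2cccs2)c2ccn[nH]2)cc1` gives 0.004 nM.

Compound 1 and compound 2 share a core. Their difference is ethyl in place of 1H-pyrazol-5-yl on an amide-type nitrogen, and in this assay it made a 3.0-fold higher number from compound 2 to compound 1 (0.48 log units; beyond the scatter). Compound 3 carries another core; the difference between the core of compound 2 and the core of compound 3 is not broken down here. Compound 3 stands lowest of the three measured values.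

Compound 4 `CCN(Cc1cccs1)C(=O)/C=C/c1ccc(C)cc1` is not yet measured. It differs from compound 3 by ethyl in place of 1H-pyrazol-5-yl on an amide-type nitrogen, the same change as from compound 2 to compound 1, at a place described in the same words. Going by these compounds, for compound 4 the expected step in this assay is a 3.0-fold higher number from compound 3 to compound 4 (0.48 log units; beyond the scatter), resting on a 3.0-fold higher number from compound 2 to compound 1 (0.48 log units; beyond the scatter) seen on the other core; whether the change carries over to the core of compound 3 is untested. Compound 4 is therefore expected at about 0.012 nM, between 0.003 nM and 0.05 nM.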

Compound 4, half-maximal effective concentration: 2 nM
Estimate against measurement, compound 4: 170-fold (2.22 log units) below, and the stated range ends below it.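

Ethyl in place of 1H-pyrazol-5-yl on the amide-type nitrogen gives a 500-fold higher number from compound 3 to compound 4 (2.70 log units; beyond the scatter) in this assay. The direction carries over between the two cores, but the size does not: the same change on two cores in this assay, a 3.0-fold higher number (0.48 log units; beyond the scatter) from compound 2 to compound 1 and a 500-fold higher number (2.70 log units; beyond the scatter) from compound 3 to compound 4, 170-fold (2.22 log units) apart, beyond the scatter of two such steps. These two pairs do not show why the size differs, nor which of the two steps is more typical of the series.

Going by these compounds, whether a longer chain or a phenyl ring on the same nitrogen would follow the larger or the smaller step remains open. Also open, on these data alone, is how an amine or a carboxylic acid at that place would read on either core.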